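Swapping methyl for amino on the outer ring

The source may report more compounds than this note shows. Statements on the series, on what has been measured and on what is new or still open speak of the compounds shown alone.

compound 1 (`COc1cc(-n2cnc3ccc(-c4cccc(O)c4)cc32)cc(OC)c1OC`): 250 nM
compound 2 (`COc1cc(-n2cnc3ccc(-c4cccc(C)c4)cc32)cc(OC)c1OC`): 3820 nM

In a functional assay on A549 cells (Homo sapiens) for antiproliferative activity, read by MTT assay, with a stated time of 72 h (on this read-out higher numbers stand for weaker inhibition and lower numbers for stronger inhibition), compound 2 has the higher of the two numbers, so it is the weaker inhibitor. Compound 3 (`COc1cc(-n2cnc3ccc(-c4cccc(N)c4)cc32)cc(OC)c1OC`) carries amino in place of methyl on an aromatic carbon. Going by the values given here, one measured step bears on this: the large rise (a 15-fold higher number from compound 1 to compound 2 (1.18 log units; beyond the scatter)) for methyl in place of hydroxy on an aromatic carbon. Among the compounds with values here, no amino compound has been measured, but losing the methyl suggests a sizeable step to a lower number in this assay is expected. For compound 3 the estimated value is 500 nM (range 120 nM to 2200 nM). This estimate means an expected step (a 7.6-fold lower number from compound 2 to compound 3 (0.88 log units; beyond the scatter)) beyond the scatter.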

Compound 3, half-maximal inhibitory concentration: 640 nM
Beside the measured number, compound 3's estimate is 1.3-fold (0.11 log units) below it, and the stated range covers the measured number.
By their numbers in this assay, from the lowest: compound 1; then compound 3; then compound 2.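

In this assay, amino in place of methyl brings a 6.0-fold lower number from compound 2 to compound 3 (0.78 log units; beyond the scatter) and so wins back much of what methyl gives up, while amino in place of hydroxy still leaves a 2.6-fold higher number from compound 1 to compound 3 (0.41 log units; beyond the scatter) to show that amino does not fully match hydroxy. This one position therefore separates all three small groups, and methyl gives the highest number. Nothing available here explains these gaps. As far as these compounds go, whether a methoxy group, a fluorine atom or a carboxylic acid would fall nearer hydroxy or nearer methyl stays open.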